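Swapping a Cyclopentylamino Group for Ethoxy on a Shared Core

A few compounds are considered here, and "the series" means these few. Any claim that something is new, unique, unknown or untested is made for them only; others in the source may bear on it.

Two compounds built on the same fused core have been examined for how strongly they harm a human leukaemia cell line, in an ADME assay on MOLT-3 cells (Homo sapiens) for cytotoxicity, with a stated time of 7 days; on this read-out lower numbers stand for higher toxicity in this test and higher numbers for lower toxicity in this test. Compound 1, with the structure `CN(C)c1nc(N)nc2c1ncn2/C=C1/CC1(CO)CO`, has in this assay only the entry "not determined" (no result reported), that is, no reported result. Compound 2, with the structure `Nc1nc(NC2CCCC2)c2ncn(/C=C3/CC3(CO)CO)c2n1`, does have an entry: in this assay compound 2 gives > 20000 nM, which is a limit of the assay rather than a measured number. Compound 2 therefore sits at the edge of what the test can report, as the limit of > 20000 nM in this assay, at which 1 of the 2 values shown sits, shows; the other entry carries no number at all, so compound 2 cannot be ranked against anything.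

Compound 3, with the structure `CCOc1nc(N)nc2c1ncn2/C=C1/CC1(CO)CO`, has not yet been measured. It differs from compound 2 in one place: ethoxy in place of cyclopentylamino on an aromatic carbon. Among the compounds with values here, since no step between two measured compounds is known here, there is nothing to scale this change against.

The step that the limit leaves unreadable from compound 2 to compound 3 is expected to stay within the scatter, with compound 3 again likely landing at the limit. Compound 3 is expected to give about 40000 nM, within a range of 15000 nM to 150000 nM.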

Compound 3, half-maximal cytotoxic concentration: > 20000 nM
Compound 3 ended at the assay's limit; the forecaster's own chance of this, stated with the estimate: 80%; the middle value lies beyond the limit too.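

In this assay compound 2 and compound 3 each give only a limit and not a measured number, so no step between them can be read: the limit of > 20000 nM in this assay, at which 2 of the 3 values shown sit.

The compounds shown leave open whether ethoxy and cyclopentylamino on the shared core differ at all in their toxicity to these cells, and by how much.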